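Trifluoromethyl in Place of Chloro at the Urea End

The source may report more compounds than this note shows. Statements on the series, on what has been measured and on what is new or still open speak of the compounds shown alone.

Compound 1 `O=C(Nc1cccc(-n2cc(-c3ccncc3)c(-c3ccc(Cl)c(O)c3)n2)c1)Nc1ccc(Cl)c(Cl)c1` is one of three compounds built on a shared core and tested for cell toxicity in a functional assay on NCI-H226 cells (Homo sapiens) for inhibition, read by sulforhodamine B assay, with a stated time of 48 h; on this read-out higher numbers stand for lower toxicity in this test and lower numbers for higher toxicity in this test. For compound 1 the result is a limit of the assay, > 32500 nM. Compound 2 `O=C(Nc1cccc(-n2cc(-c3ccncc3)c(-c3ccc(Cl)c(O)c3)n2)c1)Nc1cc(C(F)(F)F)cc(C(F)(F)F)c1` gives 37600 nM in this assay. For compound 3 `COc1cc(-c2nn(-c3cccc(NC(=O)Nc4cccc(C(F)(F)F)c4)c3)cc2-c2ccncc2)ccc1Cl` the result is again a limit, > 50000 nM. On the numbers shown, compound 1 stands at the limit of > 32500 nM in this assay, at which 1 of the 3 values shown sits, while the other limit in the set is the limit of > 50000 nM in this assay, at which 1 of the 3 values shown sits, and all three compounds sit at the low-toxicity edge of what this assay reports. For the measured compounds named here, no pair of measured compounds differs in a single place, so the set contains no measured step that shows how one change moves the number.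

Compound 4 `O=C(Nc1cccc(-n2cc(-c3ccncc3)c(-c3ccc(Cl)c(O)c3)n2)c1)Nc1ccc(Cl)c(C(F)(F)F)c1` has not been measured yet. It differs from compound 1 by trifluoromethyl in place of chloro on an aromatic carbon. Compound 2 already carries trifluoromethyl groups and gives 37600 nM, which lies where compound 1 lies. The step that the limit leaves unreadable from compound 1 to compound 4 is therefore expected to stay within the scatter, with no clear direction. Compound 4 is estimated at 40000 nM, with a likely range from 20000 nM to 80000 nM, and the test may well report only a limit.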

Compound 4, concentration lethal to 50% of the cells: > 32500 nM
Compound 4: only a limit was reported; the forecaster's own chance of this, stated with the estimate: 50%; the middle value does not contradict the limit.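

Compound 1 and compound 4 both return only a limit in this assay, and it is the same limit: the limit of > 32500 nM in this assay, at which 2 of the 4 values shown sit.

Trifluoromethyl in place of chloro therefore gives no step that can be read between compound 1 and compound 4. The compounds shown leave open whether this change alters toxicity at all, and in which direction.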